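Chloro added to the phenyl ring of compound 2

This account rests on a few compounds, and the source may have more. Where it says the series, first, only, none or still open, it means among the compounds named here.

Measured compounds in a functional assay on COLO 205 cells (Homo sapiens) for inhibition; a lower number here means a stronger inhibitor of growth, a higher number a weaker inhibitor of growth:
compound 1 `COc1cc(/C=C/C(=O)c2cccc(-n3cc(-c4ccc(Cl)cc4)[nH]c3=O)c2)cc(OC)c1OC` gives 7380 nM
compound 2 `COc1cc(/C=C/C(=O)c2cccc(-n3cc(-c4ccccc4)[nH]c3=O)c2)ccc1O` gives 2210 nM
compound 3 `COc1cc(/C=C/C(=O)c2cccc(-n3cc(-c4cc(OC)c(OC)c(OC)c4)[nH]c3=O)c2)cc(OC)c1OC` gives 1520 nM

Among these three, compound 2 stands second highest; its number lies within the scatter of that of compound 3 and is beyond the scatter below that of compound 1. Compound 4 `COc1cc(/C=C/C(=O)c2cccc(-n3cc(-c4ccc(Cl)cc4)[nH]c3=O)c2)ccc1O` differs from compound 2 by a single change: chloro in place of hydrogen on an aromatic carbon. Among the measured compounds shown here, no measured pair shows exactly this change. For the measured compounds named here, the only measured step, a 4.9-fold lower number from compound 1 to compound 3 (0.69 log units; beyond the scatter), replaces the 4-chlorophenyl group by a 3,4,5-trimethoxyphenyl group on the core of compound 1 and lowers the number modestly, so the chloro-bearing compound 1 has the highest number of the set. A phenyl to 4-chlorophenyl comparison is not available, so the direction of the step to compound 4 in this assay is uncertain; a small rise in the number, or no change beyond the scatter, is expected. Compound 4 is therefore estimated at 3500 nM, with a range from 1200 nM to 10000 nM, corresponding to an expected step of a 1.6-fold higher number from compound 2 to compound 4 (0.20 log units; within the scatter).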

Compound 4, concentration for 50% growth inhibition: 3400 nM
The estimate for compound 4 lay 1.0-fold (0.01 log units) above the measured number, within the range that was stated.
By their numbers in this assay, from the lowest: compounds 3, 2 and 4 (each within the scatter of the next, the first and the last beyond it); then compound 1.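

In this assay, among the compounds shown here, the change from phenyl to 4-chlorophenyl can now be read directly for the first time, with chloro in place of hydrogen on an aromatic carbon para to a large group giving a 1.5-fold higher number from compound 2 to compound 4 (0.19 log units; within the scatter). On the core of compound 2, this position therefore tolerates chloro, as the step stays within the scatter and this assay does not separate the two compounds. The compounds shown offer no evidence that would explain this result.

On these data alone, it remains open whether another group at this position, such as an amine, a carboxylic acid or a longer alkoxy chain, would give a step beyond the scatter. Also open, as far as these compounds go, is whether chloro in place of hydrogen would give a similar step on the core of compound 1.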